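A few compounds are considered here, and "the series" means these few. Any claim that something is new, unique, unknown or untested is made for them only; others in the source may bear on it.

Measured so far in a physicochemical assay for solubility, with a stated time of 24 h, tested at 30 mg/mL; a lower number here means a less soluble compound, a higher number a more soluble compound
Compound 1 `Cc1cc(COc2ccc(S(=O)(=O)NC3(CC(=O)NO)COC3)cc2)c2ccccc2n1` gives 200000 nM
Compound 2 `Cc1cc(COc2ccc(S(=O)(=O)NC3(CC(=O)NO)CN(C(=O)CC(C)C)C3)cc2)c2ccccc2n1` gives 900000 nM

In this assay compound 2 stands highest of the two, at 900000 nM. The gap to compound 1 lies beyond the scatter. Compound 3 `Cc1cc(COc2ccc(S(=O)(=O)NC3(CC(=O)NO)CN(C(=O)N4CCCCC4)C3)cc2)c2ccccc2n1` differs from compound 2 by one change: piperidin-1-yl in place of isobutyl on a carbonyl carbon. Among the measured compounds shown here, no measured pair differs in one place only, so the expectation is tentative: a small fall, not beyond the scatter. The estimated step is a 1.5-fold lower number from compound 2 to compound 3 (0.18 log units; within the scatter) (expected, downward). For compound 3 the expected solubility is 600000 nM (estimated range 200000 nM to 1500000 nM).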

Compound 3, solubility: 500000 nM
Compound 3: middle estimate off by 1.2-fold (0.08 log units), on the high side; the range from low to high includes it.
By their numbers in this assay, from the lowest: compound 1; then compounds 3 and 2 (each within the scatter of the next).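

In this assay, among the compounds shown here, piperidin-1-yl in place of isobutyl on a carbonyl carbon gives the first single-place step, a 1.8-fold lower number from compound 2 to compound 3 (0.26 log units; within the scatter). At this position, then, the open isobutyl chain and the six-membered non-aromatic ring read alike, even with two more heavy atoms in the entering group. No measured evidence bears on this step.

Going by these compounds, whether a longer chain, or a carboxylic acid or amine carried on this carbonyl carbon, would give a step beyond the scatter remains open. So does whether this change reads the same on another core.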